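A few compounds are considered here, and "the series" means these few. Any claim that something is new, unique, unknown or untested is made for them only; others in the source may bear on it.

Three compounds were tested in an ADME assay on BJ cells (Homo sapiens) for cytotoxicity, with a stated time of 72 h (on this read-out higher numbers stand for an effect only at larger amounts of compound and lower numbers for an effect already at smaller amounts), and none gave a number. Compound 1 (`C=C[C@@](C)(/C=C/c1ccc(O)cc1)CC/C=C(\C)CO`) gives > 36600 nM, which is a limit of the assay. Compound 2 (`C=C[C@@](C)(/C=C/c1ccc(O)c(/C=C/C(=O)OCc2ccccc2)c1)CCC=C(C)C`) gives > 36600 nM, again a limit. Compound 3 (`CC(C)=CCC[C@@](C)(/C=C/c1ccccc1)/C=C/c1ccc(O)cc1`) gives > 36600 nM, also a limit. As far as these compounds go, compound 3 therefore stands with the other two at the limit of > 36600 nM in this assay, at which 3 of the 3 values shown sit, and its exact position is unknown.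

Compound 4 (`CC(C)=CCC[C@](C)(/C=C/c1ccc(O)cc1)/C=C/c1cccc(Cl)c1`) differs from compound 3 by a single change, chloro in place of hydrogen on an aromatic carbon, which turns phenyl into 3-chlorophenyl: chloro in place of hydrogen on an aromatic carbon. Among the measured compounds shown here, no measured pair shows what such a change does in this assay. The estimated at least 1.0-fold lower number from compound 3 to compound 4 (0.00 log units; that floor lies within the scatter) is therefore none beyond the scatter, with neither direction favoured. This expectation rests on the single picture so far, (the limit of > 36600 nM in this assay, at which 3 of the 3 values shown sit), and the assay may well report only a limit again. For compound 4 the estimated value is 36000 nM, expected to fall between 15000 nM and 70000 nM.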

Compound 4, half-maximal effective concentration: > 36600 nM
Compound 4: no number, only a limit; the forecaster's own chance of this, stated with the estimate: 70%; middle value at least 1.0-fold (0.00 log units) from the limit.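

Compound 3 and compound 4 both give only a limit, and the step between them, chloro in place of hydrogen on an aromatic carbon, cannot be read. The compounds shown leave open at what value any of them would give a number: the limit of > 36600 nM in this assay, at which 4 of the 4 values shown sit.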